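A few compounds are considered here, and "the series" means these few. Any claim that something is new, unique, unknown or untested is made for them only; others in the source may bear on it.

Working notes on the series. In a functional assay on MCF7 cells (Homo sapiens) for inhibition, read by MTT assay, with a stated time of 24 h (on this read-out higher numbers stand for weaker inhibition of growth and lower numbers for stronger inhibition of growth), compound 1 (`Cn1cc(-c2nc3ccccc3n2C(=O)c2ccccc2)c2ccccc21`) gives 43700 nM on this read-out. Compound 2 (`COc1cccc(C(=O)n2c(-c3cn(C)c4ccccc34)nc3ccccc32)c1`) gives 15700 nM in the same test, and compound 3 (`COc1ccc(C(=O)n2c(-c3cn(C)c4ccccc34)nc3ccccc32)cc1`) gives 16300 nM there. Compound 3 therefore stands level with compound 2 and clearly lower than compound 1.

The next structure is compound 4 (`COc1ccc(C(=O)n2c(-c3cn(C)c4ccc(Br)cc34)nc3ccccc32)cc1`). It carries bromo in place of hydrogen on an aromatic carbon of a six-membered aromatic ring of carbon only, part of a fused or bridged system of two rings (bromo in place of hydrogen on an aromatic carbon).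

Among the measured compounds shown here, no measured step places any group on that ring, so the evidence is indirect. Adding methoxy to compound 1 gives two modest steps (a 2.8-fold lower number from compound 1 to compound 2 (0.44 log units; beyond the scatter); a 2.7-fold lower number from compound 1 to compound 3 (0.43 log units; beyond the scatter)). Changing 3-methoxyphenyl to 4-methoxyphenyl gives a step within the scatter (a 1.0-fold higher number from compound 2 to compound 3 (0.02 log units; within the scatter)). Both additions lowered the number modestly, but neither says anything directly about bromo. A modest step toward a lower number in this assay is the working expectation, and a result within the scatter would not be surprising.

The expected change is (a 1.6-fold lower number from compound 3 to compound 4 (0.21 log units; within the scatter)). Compound 4 is estimated at 10000 nM (expected range 3500 nM to 25000 nM).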

Compound 4, concentration for 50% growth inhibition: 19200 nM
The estimate for compound 4 lay 1.9-fold (0.28 log units) below the measured number; the measured number falls inside the stated range.
By their numbers in this assay, from the lowest: compounds 2, 3 and 4 (each within the scatter of the next); then compound 1.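

In this assay, bromo in place of hydrogen on an aromatic carbon of the six-membered aromatic ring of carbon only, meta to a fused ring and para to a fused ring, gives a 1.2-fold higher number from compound 3 to compound 4 (0.07 log units; within the scatter). This is the only step among the compounds shown that places a group on this ring, and it shows that one bromine atom at this position leaves the number level within the scatter, whereas the methoxy addition gave a 2.7-fold lower number from compound 1 to compound 3 (0.43 log units; beyond the scatter), a step printed as beyond the scatter. No supporting measurement bears on this result, so it stands as an observation without an explanation.

Going by these compounds, whether the level result is particular to bromo or holds for this position more generally remains open, since an amine, a carboxylic acid or a methoxy group on the same ring could move the number in either direction. Also open, on these data alone, is whether bromo at this place would give the same result with the 3-methoxyphenyl group of compound 2 or the unsubstituted phenyl group of compound 1.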